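The source may report more compounds than this note shows. Statements on the series, on what has been measured and on what is new or still open speak of the compounds shown alone.

Of the compounds shown here, three have been measured in a functional assay on A2780 cells (Homo sapiens) for inhibition; on this read-out higher numbers stand for weaker inhibition and lower numbers for stronger inhibition. Compound 1 `CCNCc1cc(-c2c(C(=O)NCC)noc2-c2cc(C(C)C)c(O)cc2O)on1` gives 45 nM. Compound 2 `CCNC(=O)c1noc(-c2cc(C(C)C)c(O)cc2O)c1-c1cc(CNC(C)C)no1` gives 38 nM, and compound 3 `CCNC(=O)c1noc(-c2cc(C(C)C)c(O)cc2O)c1-c1ccn(C)n1` gives 12 nM, the lowest of the three numbers. Compound 2 differs from compound 1 by methyl in place of hydrogen on a saturated chain carbon bound to an amine nitrogen and a saturated chain carbon, and this change produced a 1.2-fold lower number from compound 1 to compound 2 (0.07 log units; within the scatter). Compound 3 differs from compound 1 in its core, by 1-methyl-1H-pyrazol-3-yl in place of 3-((ethylamino)methyl)-1,2-oxazol-5-yl on an aromatic carbon.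

Compound 4 `CCNC(=O)c1noc(-c2cc(C(C)C)c(O)cc2O)c1-c1ccn(CC)n1` has not yet been measured. It differs from compound 3 by methyl in place of hydrogen on a saturated chain carbon bound to an aromatic nitrogen. This is the same kind of change as that from compound 1 to compound 2, but not the same: there the added methyl sat on a saturated chain carbon bound to an amine nitrogen and a saturated chain carbon, whereas here it sits on a saturated chain carbon bound to an aromatic nitrogen. Because the earlier step gave a 1.2-fold lower number from compound 1 to compound 2 (0.07 log units; within the scatter), the expected step from compound 3 to compound 4 in this assay is estimated as no change at the digits printed from compound 3 to compound 4 (within the scatter). Compound 4 is therefore expected to give about 12 nM, in a range from 6 nM to 25 nM.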

Compound 4, half-maximal inhibitory concentration: 13 nM
Beside the measured number, compound 4's estimate is 1.1-fold (0.03 log units) below it; the range from low to high includes it.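

In this assay the added methyl gave a 1.1-fold higher number from compound 3 to compound 4 (0.03 log units; within the scatter) and, set beside the earlier step, the change carried over from one core to the other without a measurable difference: the same change on two cores in this assay, a 1.2-fold lower number (0.07 log units; within the scatter) from compound 1 to compound 2 and a 1.1-fold higher number (0.03 log units; within the scatter) from compound 3 to compound 4, 1.3-fold (0.11 log units) apart, within the scatter of two such steps. This shows that on these two cores the change from hydrogen to methyl left the number where it was, once on a carbon bound to an amine nitrogen and once on a carbon bound to an aromatic nitrogen, but two pairs do not show that it would behave alike on any other core. The steps of a 2.9-fold lower number from compound 2 to compound 4 (0.47 log units; beyond the scatter) and a 3.5-fold lower number from compound 1 to compound 4 (0.54 log units; beyond the scatter) exchange the whole group on the aromatic carbon, so they say nothing about the added methyl.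

The compounds shown leave open how far the chain on the pyrazole can grow, for instance whether a propyl or butyl chain in place of the ethyl keeps the number in this range. They also leave open whether an amine at the end of such a chain would do the same.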